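Cytotoxicity notes: the alkenyl chain from compound 2 to compound 3

The source may hold more compounds than are shown below. What is called first, only, known or untested is meant among the compounds shown, and "the series" means these compounds.

In an ADME assay on L02 cells (Homo sapiens) for cytotoxicity, read by MTT assay, with a stated time of 72 h (a higher number here means a weaker inhibitor, a lower number a stronger inhibitor), compound 1 (`C=CC(=O)Nc1cccc(Oc2nc(Nc3cccc(OC)c3)nc3c2CSCC3)c1`) gives 48900 nM as its reading. Compound 2 (`CC/C=C/C(=O)Nc1cccc(Oc2nc(Nc3cccc(OC)c3)nc3c2CSCC3)c1`) gives > 50000 nM as a limit and not a number: it sits at the limit of > 50000 nM in this assay, at which 1 of the 2 values shown sits, with no exact reading. Compound 3 (`CCC/C=C/C(=O)Nc1cccc(Oc2nc(Nc3cccc(OC)c3)nc3c2CSCC3)c1`) differs from compound 2 by methyl in place of hydrogen on a saturated chain carbon, two bonds along the chain from a double-bonded chain carbon with but-1-en-1-yl becoming pent-1-en-1-yl. Among the compounds with values here, the only measured step bearing on this is an at least 1.0-fold higher number from compound 1 to compound 2 (0.00 log units; that floor lies within the scatter) and it is a bound only. The estimated step in this assay is therefore a number no higher from compound 2 to compound 3 (the limit leaves the size open) and none beyond the scatter is expected. The estimate for compound 3 is 50000 nM with an expected range from 30000 nM to 90000 nM overall.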

Compound 3, half-maximal inhibitory concentration: > 50000 nM
Compound 3 ended at the assay's limit; the forecaster's own chance of this, stated with the estimate: 75%; the middle value lies on the limit itself.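

In this assay compound 3 gives a limit and not a number: the limit of > 50000 nM in this assay, at which 2 of the 3 values shown sit.

The step from compound 2 to compound 3 cannot be read, as both readings are limits. What can be read is an at least 1.0-fold higher number from compound 1 to compound 3 (0.00 log units; that floor lies within the scatter), so the added methyl brings no exact reading into range.

On these data alone, how far compound 2 and compound 3 lie past the limit stays open. As far as these compounds go, whether a longer chain, or an amine or a carboxylic acid at the chain end, would give an exact reading also stays open.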